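The compounds below may be only part of what the source reports. "The series", "measured", "known", "first", "only" and "open" are said of these compounds alone.

Compound 3 `CN1CCN(c2ccc(Nc3nc(-c4cccc(NC(=O)c5ccccc5F)c4)sc3C(=O)O)cc2)CC1` is one of three compounds that share a core and differ only in the benzoyl amide and in an acid or ester group. In a functional assay on Ramos cells (Homo sapiens) for antiproliferative activity, read by CCK-8 assay, with a stated time of 72 h, tested at 40 uM (on this read-out higher numbers stand for more inhibition at the one concentration tested (going by the name of the read-out) and lower numbers for less inhibition), compound 3 gives 93.4%. Compound 1 `CCOC(=O)c1sc(-c2cccc(NC(=O)c3ccccc3F)c2)nc1Nc1ccc(N2CCN(C)CC2)cc1` gives 96.4%, and compound 2 `CN1CCN(c2ccc(Nc3nc(-c4cccc(NC(=O)c5ccccc5)c4)sc3C(=O)O)cc2)CC1` gives 26.3%; compound 3 stands second highest of the three, within the scatter of compound 1 and far above compound 2. The step of a number 3 percentage points lower from compound 1 to compound 3 (within the scatter) shows that the ester change matters little, whereas a number 67.1 percentage points higher from compound 2 to compound 3 (beyond the scatter) shows that a single fluorine on the benzoyl ring changes much. Compound 4 `CN1CCN(c2ccc(Nc3nc(-c4cccc(NC(=O)c5ccc(F)c(Cl)c5)c4)sc3C(=O)O)cc2)CC1` differs from compound 3 by 3-chloro-4-fluorophenyl in place of 2-fluorophenyl on a carbonyl carbon. Among the measured compounds shown here, the fluorine is kept but moved, and a chlorine is added, so the one relevant step points both ways. For compound 4 a middle value of 60% is expected, with a range from 15% to 95%, which means an expected step of a number 33.4 percentage points lower from compound 3 to compound 4 (beyond the scatter).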

Compound 4, a percentage reported as inhibition, at one concentration (the size of the read-out at that concentration, not a potency): 98.6%
Compound 4: the middle estimate sits 38.6 percentage points below what was measured; the whole stated range lies below it.
By their numbers in this assay, from the lowest: compound 2; then compounds 3, 1 and 4 (each within the scatter of the next).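

In this assay a step of a number 5.2 percentage points higher from compound 3 to compound 4 (within the scatter) shows that 3-chloro-4-fluorophenyl and 2-fluorophenyl cannot be told apart on the carbonyl carbon. The step of a number 72.3 percentage points higher from compound 2 to compound 4 (beyond the scatter) confirms that the large gain over plain phenyl is not confined to 2-fluorophenyl. Nothing available explains why these substituted rings read so differently from phenyl. From the compounds shown here alone, whether a halogen is needed remains open, since a ring bearing methoxy or an amine could read either way. A single-halogen comparison, such as 3-chlorophenyl or 4-fluorophenyl, would show which atom matters here.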